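The source may hold more compounds than are shown below. What is called first, only, known or untested is meant among the compounds shown, and "the series" means these compounds.

Compound 1 `Fc1ccc2c(Cn3ccnc3)c(-c3ccc(Cl)cc3)[nH]c2c1` — in an assay on isolated protein for inhibition of Aromatase (Homo sapiens), read by ELISA, using NADPH, with a stated time of 24 h (a higher number here means a weaker inhibitor, a lower number a stronger inhibitor), compound 1 gives 82.9 nM
Compound 2 `COc1ccc2c(Cn3ccnc3)c(-c3ccc(F)cc3)[nH]c2c1` — in this assay compound 2 gives 109 nM

Compound 2 has the higher of the two numbers, but its gap to compound 1 lies within the scatter, so the two cannot be told apart. Compound 3 `COc1ccc2c(Cn3ccnc3)c(-c3ccc(Cl)cc3)[nH]c2c1` keeps the core of compound 2 and carries chloro in place of fluoro on an aromatic carbon. Among the compounds with values here, no pair of measured compounds differs in just one place, so there is no measured step to lean on. In this assay this change is expected to move the number little, if at all beyond the scatter. The estimate for compound 3 is 90 nM, in the range 40 nM to 200 nM, an expected step of a 1.2-fold lower number from compound 2 to compound 3 (0.08 log units; within the scatter).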

Compound 3, half-maximal inhibitory concentration: 1060 nM
Compound 3: middle estimate off by 12-fold (1.07 log units), on the low side, and the stated range ends below it.
By their numbers in this assay, from the lowest: compounds 1 and 2 (each within the scatter of the next); then compound 3.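

Swapping one halogen on an aromatic carbon, para to a large group, is no minor edit here: in this assay 4-fluorophenyl to 4-chlorophenyl gives a 9.7-fold higher number from compound 2 to compound 3 (0.99 log units; beyond the scatter). With the chloro kept, methoxy in place of fluoro on the shared core gives a 13-fold higher number from compound 1 to compound 3 (1.11 log units; beyond the scatter), so a single change at either place can weaken inhibition. Nothing measured here explains these steps.

Still open, from the compounds shown here alone, is whether fluoro to chloro would give a step of this size with fluoro rather than methoxy on the core. Also open, going by these compounds, is how a nitrile or a methyl group would read in place of the halogen.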